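The compounds below may be only part of what the source reports. "The series", "measured", "known", "first", "only" and "open" are said of these compounds alone.

Compound 3 `Nc1nc(N)nc(-c2ccccc2Br)n1` is the lowest of the three measured compounds: in a physicochemical assay for lipophilicity (on this read-out higher numbers stand for higher lipophilicity and lower numbers for lower lipophilicity), compound 3 gives 1.26, whereas compound 2 `Nc1nc(N)nc(-c2cc(Cl)ccc2Br)n1` gives 1.85 and compound 1 `Nc1nc(N)nc(-c2cc(Br)ccc2Br)n1` gives 2.09. Compound 4 `Nc1nc(N)nc(-c2ccc(Cl)cc2Br)n1` differs from compound 3 in one place: chloro in place of hydrogen on an aromatic carbon. For the measured compounds named here, the closest precedent runs the other way, a number 0.59 log units lower from compound 2 to compound 3 (beyond the scatter), and the halogen steps a number 0.83 log units lower from compound 1 to compound 3 (beyond the scatter) and a number 0.24 log units lower from compound 1 to compound 2 (within the scatter) are consistent with it. On that basis a modest rise beyond the scatter is expected in this assay, about the size of the earlier chloro-for-hydrogen step reversed; the expected step is a number 0.59 log units higher from compound 3 to compound 4 (beyond the scatter). Compound 4 is therefore estimated at 1.85, with a likely range from 1.5 to 2.2.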

Compound 4, partition coefficient: 2.09
Estimate against measurement, compound 4: 0.24 log units below; the measured number falls inside the stated range.
By their numbers in this assay, from the lowest: compound 3; then compounds 2, 1 and 4 (each within the scatter of the next).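

In this assay, chloro on this aromatic carbon, para to a group of 8 heavy atoms and meta to a bromo group, brings a modest rise, a number 0.83 log units higher from compound 3 to compound 4 (beyond the scatter). For the compounds shown here, the earlier compounds gave a chloro step only at another place, a number 0.59 log units lower from compound 2 to compound 3 (beyond the scatter), so this is the first reading at this position, and its direction agrees with that step reversed. Nothing available explains the rise. From the compounds shown here alone, whether a methoxy group, an amine or a carboxylic acid on this carbon would move the number the same way stays open.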